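Iodo in place of chloro: compound 3 to compound 4

This account rests on a few compounds, and the source may have more. Where it says the series, first, only, none or still open, it means among the compounds named here.

In a functional assay on HEL cells (Homo sapiens) for cytotoxicity (a higher number here means that more compound is tolerated, a lower number that less compound is tolerated), compound 3 (`O=c1nc2oc(CCCCCCCCCCl)cc2cn1[C@H]1C[C@H](O)[C@@H](CO)O1`) stands at 200000 nM and level with compound 2 (`O=c1nc2oc(CCCCCCCCCF)cc2cn1[C@H]1C[C@H](O)[C@@H](CO)O1`), which gives 200000 nM with fluoro in place of the chloro. Compound 1 (`O=c1[nH]c(=O)n([C@H]2C[C@H](O)[C@@H](CO)O2)cc1C#CCCCCCCCCCF`), built on a different core, gives 116000 nM and lies within the scatter of both.

Compound 4 (`O=c1nc2oc(CCCCCCCCCI)cc2cn1[C@H]1C[C@H](O)[C@@H](CO)O1`) differs from compound 3 by iodo in place of chloro on a saturated chain carbon, nine bonds along the chain from an aromatic carbon and so carries iodo in place of chloro on a saturated chain carbon, nine bonds along the chain from an aromatic carbon. For the measured compounds named here, one measured step bears on this: chloro in place of fluoro at that same place gives no change at the digits printed from compound 2 to compound 3 (within the scatter) and nothing more. Going by the values given here, no measured compound carries iodo, so this single step is a thin guide. In this assay no step beyond the scatter is expected, and the estimated step is a 1.1-fold lower number from compound 3 to compound 4 (0.05 log units; within the scatter) on this evidence. For compound 4 the expected value is 180000 nM with an estimated range from 90000 nM to 250000 nM around it.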

Compound 4, half-maximal cytotoxic concentration: > 200000 nM
Compound 4 ended at the assay's limit; the forecaster's own chance of this, stated with the estimate: 35%; middle value at least 1.1-fold (0.04 log units) from the limit.
By their numbers in this assay, from the lowest: compounds 1, 2 and 3 (each within the scatter of the next).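

In this assay compound 4 gives > 200000 nM, a limit of the assay and not a number. It shows that iodo at this place on the saturated chain carbon, like fluoro and chloro before it, brings no lower number, so the tolerance seen with the two lighter halogens holds for a third. The data give a number no lower from compound 3 to compound 4 (the limit leaves the size open) and a number no lower from compound 2 to compound 4 (the limit leaves the size open) but neither step can be read for size, and the result marks only the top of the range that the assay reports: the limit of > 200000 nM in this assay, at which 1 of the 4 values shown sits.

On these data alone, how far compound 4 lies past that limit stays open, and with it whether iodo differs from chloro here at all. Also open, as far as these compounds go, is whether an amine or a carboxylic acid in place of iodo on that carbon, or a shorter chain, would lower the number on the shared core.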